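Swapping the five-membered ring on the shared core

The source may hold more compounds than are shown below. What is called first, only, known or untested is meant among the compounds shown, and "the series" means these compounds.

Measured so far in a functional assay on HeLa cells (Homo sapiens) for cytotoxicity, read by CCK-8 assay; a lower number here means a stronger inhibitor, a higher number a weaker inhibitor:
compound 1 `Oc1cccc(-c2cc(-c3ccsc3)cc(-c3ccccc3O)n2)c1`: > 50000 nM
compound 2 `Oc1cccc(-c2cc(-c3ccsc3)cc(-c3cccc(O)c3)n2)c1`: 16600 nM
compound 3 `Oc1ccc(-c2cc(-c3ccsc3)cc(-c3cccc(O)c3)n2)cc1`: 2580 nM

The value of compound 1 is a limit of the assay and not a number. Compound 2 gives 16600 nM in this assay, the higher of the two numbers in hand; its nearest neighbour is compound 3, with a 6.4-fold lower number from compound 2 to compound 3 (0.81 log units; beyond the scatter). The remaining entry, that of compound 1, is the limit (the limit of > 50000 nM in this assay, at which 1 of the 3 values shown sits).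

Compound 4 `Oc1cccc(-c2cc(-c3ccco3)cc(-c3cccc(O)c3)n2)c1` differs from compound 2 in one place: furan-2-yl in place of thiophen-3-yl on an aromatic carbon. Among the measured compounds shown here, none of the measured steps touches this five-membered ring. Each of them instead moves the hydroxyl on one hydroxyphenyl group of the shared core: an at least 3.0-fold lower number from compound 1 to compound 2 (0.47 log units; beyond the scatter), an at least 19-fold lower number from compound 1 to compound 3 (1.28 log units; beyond the scatter) and a 6.4-fold lower number from compound 2 to compound 3 (0.81 log units; beyond the scatter). These steps show that the hydroxyl position matters in this assay, from modest to large, but they carry no information on exchanging thiophen-3-yl for furan-2-yl. For the measured compounds named here, with no measured step bearing on this change, the expectation is no step beyond the scatter, held with a wide range. For compound 4 the expected value in this assay is 16000 nM, between 6000 nM and 45000 nM. This estimate is expected to mean a 1.0-fold lower number from compound 2 to compound 4 (0.02 log units; within the scatter).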

Compound 4, half-maximal inhibitory concentration: 5990 nM
For compound 4 the middle estimate is 2.7-fold (0.43 log units) above the measured one; measured number outside the range, below it.
By their numbers in this assay, from the lowest: compound 3; then compound 4; then compound 2. At a limit, above all of these: compound 1.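

Among the compounds shown here, the five-membered ring, constant in the earlier compounds, proves able to move the read-out in this assay: furan-2-yl in place of thiophen-3-yl, opposite the ring nitrogen, gives a 2.8-fold lower number from compound 2 to compound 4 (0.44 log units; beyond the scatter) with the hydroxyl groups unchanged. So the hydroxyl position is not the only part of the shared core that matters here, and the step appears although the two groups match in heavy atoms, ring size and counted hydrogen-bond donors and acceptors. The exchange alters two things at once, sulfur to oxygen and a 3-yl to a 2-yl attachment, and no measurement shown gives a reason for the step or assigns it to either change.

Open, on these data alone, is whether the furan-2-yl exchange carries over to the core of compound 3, which holds a 4-hydroxyphenyl group and gives 2580 nM with thiophen-3-yl, or whether the step depends on the hydroxyl pattern of compound 2. Also open, as far as these compounds go, is how thiophen-2-yl or furan-3-yl would separate the hetero atom from the attachment point, and whether an amine or a longer alkyl chain is tolerated at this position at all.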